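One Measured Value and a Changed Amide

The source may hold more compounds than are shown below. What is called first, only, known or untested is meant among the compounds shown, and "the series" means these compounds.

Compounds so far in a functional assay on L6 cells (Rattus norvegicus) for inhibition (a higher number here means a weaker inhibitor, a lower number a stronger inhibitor), are these:
Compound 1 `COc1ccc(CNC(=O)c2nn(-c3ccc(F)cc3)c(OC[C@@H](O)C[C@@H](O)CC(=O)O)c2C(C)C)cc1` - "not determined" (no result reported)
Compound 2 `CC(C)c1c(C(=O)NCc2cccc(Cl)c2)nn(-c2ccc(F)cc2)c1OC[C@@H](O)C[C@@H](O)CC(=O)O` - "not determined" (no result reported)
Compound 3 `CC(C)c1c(C(=O)NCc2ccccc2Cl)nn(-c2ccc(F)cc2)c1OC[C@@H](O)C[C@@H](O)CC(=O)O` - 8450 nM

Only compound 3 has a number, a half-maximal inhibitory concentration of 8450 nM in this set. Compound 1 and compound 2 have no result, so compound 3 cannot yet be ranked against anything.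

Compound 4 `CC(C)c1c(C(=O)N(C)Cc2cccc(F)c2)nn(-c2ccc(F)cc2)c1OC[C@@H](O)C[C@@H](O)CC(=O)O` has not been measured. It keeps the shared core and differs from compound 3 only in the amide ((3-fluorobenzyl)(methyl)amino in place of (2-chlorobenzyl)amino on a carbonyl carbon). In words, (3-fluorobenzyl)(methyl)amino stands in place of (2-chlorobenzyl)amino on a carbonyl carbon, and the entering group has no hydrogen-bond donors.

Going by the values given here, no measured pair shows how a change of this kind moves the read-out in this assay at all. Among the compounds with values here, the only anchor is compound 3 at 8450 nM in this series, and one value gives no direction, so no step beyond the usual scatter is expected. The expected change (a 1.1-fold lower number from compound 3 to compound 4 (0.02 log units; within the scatter)) is therefore small, though the uncertainty around it is wide. The estimate for compound 4 is 8000 nM in this assay, with the expected range wide (from 2000 nM to 30000 nM).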

Compound 4, half-maximal inhibitory concentration: 2470 nM
For compound 4 the middle estimate is 3.2-fold (0.51 log units) above the measured one, and the stated range covers the measured number.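

Going by these compounds alone, the amide on the shared core is the first place where a change can be read: in this assay, putting (3-fluorobenzyl)(methyl)amino in place of (2-chlorobenzyl)amino on the carbonyl carbon gives a 3.4-fold lower number from compound 3 to compound 4 (0.53 log units; beyond the scatter) and makes a modest step that lies beyond the usual scatter of repeated measurements. The read-out therefore responds to what sits on this carbonyl carbon, and losing the amide hydrogen does not abolish inhibition in these cells, since compound 4 is the stronger inhibitor of the two. No measured information comes with this step to say why the number falls, and the comparison alone cannot tie the change to any one feature of the groups.

Several things change at once here, namely chlorine to fluorine, the 2- to the 3- label on the benzyl group and the added methyl, so it remains open which of them carries the step. From the compounds shown here alone, it also remains open how this assay would read with a different group on the same carbonyl carbon, such as a morpholine ring or a longer 2-phenylethylamino chain.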